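Permeability step from trifluoroethoxy to isopropyl in the acylurea series

This account rests on a few compounds, and the source may have more. Where it says the series, first, only, none or still open, it means among the compounds named here.

Three members of the series have numbers in an ADME assay on LLC-PK1 cells (Sus scrofa) for permeability; on this read-out lower numbers stand for lower permeability and higher numbers for higher permeability. Compound 1 `COc1ccccc1C(=O)NC(=O)Nc1ccc(-c2nccs2)c(C(F)(F)F)c1` gives 12 10^-6 cm/s in this assay. Compound 3 `COc1ccncc1C(=O)NC(=O)Nc1ccc(-c2ccccc2)c(C(F)(F)F)c1` gives 2.3 10^-6 cm/s in this assay. Compound 2 `COc1ccccc1C(=O)NC(=O)Nc1ccc(OCC(F)(F)F)c(C(F)(F)F)c1` returns only a limit in this assay, < 1 10^-6 cm/s, so no number is known for it. Compound 2 thus sits at the floor of what this assay reports, at the limit of < 1 10^-6 cm/s in this assay, at which 1 of the 3 values shown sits.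

Among the compounds with values here, the one single-point step that touches this floor is an at least 12-fold lower number from compound 1 to compound 2 (1.07 log units; beyond the scatter), the exchange of 1,3-thiazol-2-yl for 2,2,2-trifluoroethoxy on an aromatic carbon. Compound 4 `COc1ccccc1C(=O)NC(=O)Nc1ccc(C(C)C)c(C(F)(F)F)c1` has not been measured. It differs from compound 2 by isopropyl in place of 2,2,2-trifluoroethoxy on an aromatic carbon. Within the data shown here, no measured pair shows isopropyl directly, so the only guide is that removing 2,2,2-trifluoroethoxy from compound 2 is the reverse of the step that drove compound 1 down to the limit.

On that basis the expected step in this assay is an at least 5.0-fold higher number from compound 2 to compound 4 (0.69 log units; beyond the scatter), upward and beyond the scatter. Compound 4 is estimated at 5 10^-6 cm/s, within 1.5 10^-6 cm/s to 15 10^-6 cm/s, with a fair chance that the assay again reports only the limit.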

Compound 4, apparent permeability: 2.1 10^-6 cm/s
Beside the measured number, compound 4's estimate is 2.4-fold (0.38 log units) above it; measured number inside the range.
By their numbers in this assay, from the lowest: compounds 4 and 3 (each within the scatter of the next); then compound 1. At a limit, below all of these: compound 2.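

In this assay, placing isopropyl instead of 2,2,2-trifluoroethoxy on the aromatic carbon ortho to a trifluoromethyl group gives an at least 2.1-fold higher number from compound 2 to compound 4 (0.32 log units; beyond the scatter), so a group with no ring can also carry the series off the floor at this position. The comparison with the thiazole gives a 5.7-fold lower number from compound 1 to compound 4 (0.76 log units; beyond the scatter), which leaves three groups at this one position in a clear order: 1,3-thiazol-2-yl highest, isopropyl in the middle and 2,2,2-trifluoroethoxy lowest, with every step between them beyond the scatter. Going by these compounds, the true size of the gain over the trifluoroethoxy group stays open, and the step is only a lower bound because compound 2 has a limit and not a number: the limit of < 1 10^-6 cm/s in this assay, at which 1 of the 4 values shown sits.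

With only these three groups compared on the shared core, the oxygen, the fluorine atoms and the ring cannot be separated as the source of the differences, and a plain ethoxy, a cyclopropyl or a morpholine at the same position would begin to divide them. On these data alone, compound 3 differs from each of the others in more than one place, so it says nothing about this position, and whether the order of the groups holds with the methoxypyridine-type change in the other half of the molecule is unknown.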